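Pyrazolyl regiochemistry swap on the shared core: clearance notes

The source may report more compounds than this note shows. Statements on the series, on what has been measured and on what is new or still open speak of the compounds shown alone.

Measured so far:
compound 1, `N#CC[C@]1(n2cc(-c3nc(-c4cn[nH]c4)cn4nccc34)cn2)C[C@H](C#N)C1`, 19 uL/min
compound 2, `N#CC[C@]1(n2cc(-c3nc(-c4cc[nH]n4)cn4nccc34)cn2)C[C@@H](C#N)C1`, 20 uL/min

Both compounds were run in an ADME assay on microsomes from liver (Homo sapiens) for pharmacokinetics; on this read-out higher numbers stand for fast clearance and lower numbers for slow clearance. Compound 2 gives 20 uL/min and compound 1 gives 19 uL/min; the two numbers lie within the usual scatter of each other, so the series shows no separation on this read-out so far. Within the data shown here, no step between measured compounds that differ in one place is available, and nothing about the shared core itself can be read from these two values alone.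

Compound 3, `N#CC[C@]1(n2cc(-c3nc(-c4cn[nH]c4)cn4nccc34)cn2)C[C@@H](C#N)C1`, has not yet been measured in this assay. Its structural relation to compound 2 is 1H-pyrazol-4-yl in place of 1H-pyrazol-3-yl on an aromatic carbon. Compound 1 also carries the 1H-pyrazol-4-yl group and gives 19 uL/min, which sits on top of compound 2.

On that basis the step from compound 2 to compound 3 is expected to be a 1.1-fold lower number from compound 2 to compound 3 (0.02 log units; within the scatter), nothing beyond the scatter in either direction. Compound 3 is therefore estimated at 19 uL/min, with a range of 10 uL/min to 38 uL/min in this assay, because compound 1 gives 19 uL/min and compound 2 gives 20 uL/min.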

Compound 3, intrinsic clearance in a liver preparation (reported as CLH), per the amount of preparation that the assay uses in the Homo sapiens assay: 44 uL/min
The estimate for compound 3 lay 2.3-fold (0.36 log units) below the measured number; measured number above the stated range.
By their numbers in the Homo sapiens assay, from the lowest: compounds 1 and 2 (each within the scatter of the next); then compound 3.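

In the Homo sapiens assay the exchange at this aromatic carbon gives a 2.2-fold higher number from compound 2 to compound 3 (0.34 log units; beyond the scatter), so the position does respond to which pyrazolyl isomer it carries, once the configuration is held fixed; the earlier pair of compound 1 and compound 2 differed in more than one place and could not show this. In the Homo sapiens assay the 1H-pyrazol-4-yl series also separates by configuration, with a 2.3-fold higher number from compound 1 to compound 3 (0.36 log units; beyond the scatter), a step that can be assigned to stereochemistry alone on this evidence: the fact that compounds 1 and 3 differ only in the configuration as drawn. In a physicochemical assay for lipophilicity, using the shake flask method, in phosphate buffer, measured as octanol-water partition, at pH 7.4 (a higher number here means a more lipophilic compound, a lower number a more polar compound), compound 2 gives 1.7 and compound 3 gives 1.6, with a number 0.10 log units lower from compound 2 to compound 3 (within the scatter), so the clearance step of this pair comes with no separation on the lipophilicity read-out.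

The compounds shown leave open whether the pyrazolyl exchange would give a similar step in the mirror-image configuration, since the series holds only the one matched pair for this change. They also leave open how clearance would respond to a group of another kind on the same aromatic carbon, such as an amine or a carboxylic acid.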